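Fluoro for methyl on the benzamide ring: compound 4

A few compounds are considered here, and "the series" means these few. Any claim that something is new, unique, unknown or untested is made for them only; others in the source may bear on it.

Measured so far:
compound 1 `Cn1c(-c2cccc(Cl)c2)cnc1NC(=O)c1ccc(F)cc1` gives > 50000 nM in a toxicity assay on THP-1 cells (Homo sapiens) for inhibition (on this read-out higher numbers stand for lower toxicity in this test and lower numbers for higher toxicity in this test), a limit of the assay rather than a number.
compound 2 `COc1cccc(-c2cnc(NC(=O)c3ccc(F)cc3)n2C)c1` gives > 100000 nM in this assay, again a limit.
compound 3 `Cc1ccc(C(=O)Nc2ncc(-c3ccccc3)n2C)cc1` gives > 50000 nM in this assay, again a limit.

Compound 3 thus stands only at a limit; the other two values are limits too, as the limit of > 50000 nM in this assay, at which 2 of the 3 values shown sit, and the limit of > 100000 nM in this assay, at which 1 of the 3 values shown sits, show. Compound 4 `Cn1c(-c2ccccc2)cnc1NC(=O)c1ccc(F)cc1` differs from compound 3 by fluoro in place of methyl on an aromatic carbon. Going by the values given here, no measured step involves this change; the one measured step, a step that the two limits leave unreadable from compound 1 to compound 2, concerns the other aromatic ring and is itself unreadable between two limits. The expectation for compound 4 in this assay is therefore another limit, estimated at 80000 nM (range 40000 nM to 200000 nM), the expected step that the limit leaves unreadable from compound 3 to compound 4 being no change beyond scatter.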

Compound 4, half-maximal cytotoxic concentration: > 100000 nM
Compound 4 ended at the assay's limit (the forecaster's own chance of this, stated with the estimate: 85%); at least 1.2-fold (0.09 log units) between middle value and limit.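

Going by these compounds alone, no step among compound 1, compound 2, compound 3 and compound 4 can be read in this assay: all four values are limits. The compounds shown leave open where each true half-maximal cytotoxic concentration lies, and whether these substitutions change it.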